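The compounds below may be only part of what the source reports. "The series", "measured", "known", "first", "only" and "open" are said of these compounds alone.

Series on a shared core. In a functional assay on A549 cells (Homo sapiens) for inhibition, read by CCK-8 assay, with a stated time of 48 h (a lower number here means a stronger inhibitor, a higher number a weaker inhibitor), compound 1 `O=C(NC(=S)Nc1ccc(F)cc1)c1cn(-c2ccccc2)nc1-c1ccc(F)cc1` gives 3540 nM. Compound 2 `O=C(NC(=S)Nc1ccc(Cl)cc1)c1cn(-c2ccccc2)nc1-c1ccc(Cl)cc1` gives 3150 nM and compound 3 `Cc1ccc(NC(=S)NC(=O)c2cn(-c3ccccc3)nc2-c2ccc(F)cc2)cc1` gives 2080 nM; both values lie within the scatter of compound 1, so the three measured compounds are not separated by this read-out. The change leading to compound 4 `Cc1ccc(-c2nn(-c3ccccc3)cc2C(=O)NC(=S)Nc2ccc(F)cc2)cc1` is methyl in place of fluoro on an aromatic carbon. Among the compounds with values here, the only measured step of the same kind, methyl in place of fluoro on an aromatic carbon, is a 1.7-fold lower number from compound 1 to compound 3 (0.23 log units; within the scatter). Nothing measured moves beyond the scatter, so for compound 4 the step of a 1.4-fold lower number from compound 1 to compound 4 (0.13 log units; within the scatter) is expected to stay within it, if anything toward a lower number. Compound 4 is estimated at 2600 nM, with a range of 1200 nM to 5600 nM.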

Compound 4, half-maximal inhibitory concentration: 3420 nM
Beside the measured number, compound 4's estimate is 1.3-fold (0.12 log units) below it, and the stated range covers the measured number.
By their numbers in this assay, from the lowest: compounds 3, 2, 4 and 1 (each within the scatter of the next).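

In this assay, 4-fluorophenyl to 4-methylphenyl at the second such group of compound 1 gives a 1.0-fold lower number from compound 1 to compound 4 (0.01 log units; within the scatter). With a 1.7-fold lower number from compound 1 to compound 3 (0.23 log units; within the scatter) at the first such group, the same change stays within the scatter at both places, so neither place is yet shown to respond to it. No measurement bearing on this result is available.

Still open, going by these compounds, is whether an amine, a carboxylic acid or a longer chain in place of fluoro at this position would move the number beyond the scatter.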